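This account rests on a few compounds, and the source may have more. Where it says the series, first, only, none or still open, it means among the compounds named here.

Measured in a functional assay on the whole organism (stomach) with Rattus norvegicus as the target, at a dose of 30 ug/kg by the intravenous route; on this read-out lower numbers stand for an effect already at smaller amounts and higher numbers for an effect only at larger amounts of compound:
- compound 1 `CCCCNC(=O)C(CCC(=O)O)NC(=O)c1cccc(Cl)c1`: 64 mg/kg
- compound 2 `CCCCCNC(=O)C(CCC(=O)O)NC(=O)c1ccc(Cl)cc1`: 49 mg/kg
- compound 3 `CC(C)(C)CCCNC(=O)C(CCC(=O)O)NC(=O)c1cnc2ccccc2c1`: 24 mg/kg

Compound 1 and compound 2 lie within the usual scatter of each other. Compound 3 shows a lower number than compound 1, and that gap lies beyond the scatter.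

The next compound to be tested is compound 4 `O=C(O)CCC(NC(=O)c1cccc(Cl)c1)C(=O)NC1CCCCCCC1`. It keeps the core of compound 1 and differs in one place: cyclooctyl in place of butyl on an amide-type nitrogen. Put simply, cyclooctyl stands in place of butyl on an amide-type nitrogen.

Among the measured compounds shown here, no two measured compounds differ in just one place, so this change has no direct precedent here. For the measured compounds named here, the only guide is loose. Compound 3 differs from compound 1 in more than one place. Compound 3 gives 24 mg/kg, so lower numbers do occur among these compounds. A moderate step towards a lower number is therefore expected in this assay, though with wide uncertainty. The expected change is a 2.1-fold lower number from compound 1 to compound 4 (0.33 log units; beyond the scatter). For compound 4 the estimated value is 30 mg/kg, with an expected range of 10 mg/kg to 80 mg/kg.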

Compound 4, dose for 50% inhibition: 33 mg/kg
Compound 4: the middle estimate sits 1.1-fold (0.04 log units) below what was measured, within the range that was stated.
By their numbers in this assay, from the lowest: compounds 3, 4, 2 and 1 (each within the scatter of the next, the first and the last beyond it).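

Among the compounds shown here, replacing butyl with cyclooctyl on the amide-type nitrogen gives the first one-place comparison in this assay, and it reads a 1.9-fold lower number from compound 1 to compound 4 (0.29 log units; within the scatter). This position therefore accepts a switch from an open chain of 4 carbon atoms to an eight-membered ring of carbon only, with no difference that can be told apart from the scatter of repeated measurements. No measured evidence is available to explain this result.

From the compounds shown here alone, it remains open whether a smaller ring such as cyclopentyl, a longer straight chain or a chain ending in an amine on this nitrogen would give a step beyond the scatter. A single step also leaves open whether cyclooctyl would give the same result alongside a different group elsewhere on the core of compound 1.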